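Cyclohexylamino for pyrrolidinyl on a fused tetracyclic quinone core

The source may hold more compounds than are shown below. What is called first, only, known or untested is meant among the compounds shown, and "the series" means these compounds.

Compound 1, `O=C1C(Nc2ccc(I)cc2)=CC(=O)c2c1nc1n2[C@H]2OC[C@@H](O)[C@H]2OC1`: 2150 nM
Compound 2, `O=C1C(Nc2ccccc2)=CC(=O)c2c1nc1n2[C@H]2OC[C@@H](O)[C@H]2OC1`: 1830 nM
Compound 3, `O=C1C(N2CCCC2)=CC(=O)c2c1nc1n2[C@H]2OC[C@@H](O)[C@H]2OC1`: > 16000 nM

Of the compounds shown here, three sharing one core have been tested in a functional assay on MGC-803 cells (Homo sapiens) for inhibition, read by sulforhodamine B assay; a lower number here means a stronger inhibitor, a higher number a weaker inhibitor. Compound 1 gives 2150 nM and compound 2 gives 1830 nM; the step of a 1.2-fold lower number from compound 1 to compound 2 (0.07 log units; within the scatter) is within the scatter. Compound 3 is recorded only as a limit of the assay, > 16000 nM, and so it stands at the weak end of the series without a fixed number (the limit of > 16000 nM in this assay, at which 1 of the 3 values shown sits). The steps of an at least 7.4-fold higher number from compound 1 to compound 3 (0.87 log units; beyond the scatter) and an at least 8.7-fold higher number from compound 2 to compound 3 (0.94 log units; beyond the scatter) show that exchanging either arylamino group for pyrrolidin-1-yl costs at least a modest amount of potency.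

Compound 4, `O=C1C(NC2CCCCC2)=CC(=O)c2c1nc1n2[C@H]2OC[C@@H](O)[C@H]2OC1`, has not yet been measured. It differs from compound 3 by cyclohexylamino in place of pyrrolidin-1-yl on a double-bonded ring carbon. The two steps into compound 3 are the ones that bear on this change, since compound 4 again carries an amino group attached through a hydrogen-bearing nitrogen rather than pyrrolidin-1-yl, so a downward step in this assay is expected, though a cyclohexyl ring is not an aryl ring and the size is uncertain. The step of an at least 4.0-fold lower number from compound 3 to compound 4 (0.60 log units; beyond the scatter) is therefore estimated for compound 4. Compound 4 is expected to give about 4000 nM, within the range 1200 nM to 16000 nM.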

Compound 4, half-maximal inhibitory concentration: > 8000 nM
Compound 4: no number, only a limit (the forecaster's own chance of this, stated with the estimate: 25%); middle value at least 2.0-fold (0.30 log units) from the limit.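

In this assay compound 4 is recorded only as a limit of the assay: the limit of > 8000 nM in this assay, at which 1 of the 4 values shown sits.

Cyclohexyl in place of phenyl on the amine nitrogen gives an at least 4.3-fold higher number from compound 2 to compound 4 (0.64 log units; beyond the scatter), and cyclohexyl in place of 4-iodophenyl gives an at least 3.7-fold higher number from compound 1 to compound 4 (0.57 log units; beyond the scatter), so in these compounds keeping a hydrogen on the amine nitrogen does not by itself keep the potency of the two arylamino compounds, a point that compound 3, which has no such hydrogen, could not settle. Compound 3 and compound 4 are both limits, and the step between them cannot be read.

On these data alone, the order of compound 3 and compound 4 therefore stays open. Also open, as far as these compounds go, is whether the potency of compound 1 and compound 2 needs an aryl ring directly on the amine nitrogen, or whether benzylamino or pyridinylamino at this carbon would keep it.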